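This account rests on a few compounds, and the source may have more. Where it says the series, first, only, none or still open, it means among the compounds named here.

In a functional assay on MCF7 cells (Homo sapiens) for cytotoxicity, read by MTT assay, with a stated time of 72 h (a higher number here means a weaker inhibitor, a lower number a stronger inhibitor), compound 1 `COc1cccc(CNC(=O)c2nc(Br)c3cccnc3c2N[C@H]2CC[C@H](N)CC2)c1` has no number, and its entry reads "not determined" (no result reported). Compound 2 `N[C@H]1CC[C@H](Nc2c(C(=O)NCc3ccccn3)nc(Br)c3cccnc23)CC1` gives 15000 nM and compound 3 `N[C@H]1CC[C@H](Nc2c(C(=O)NCc3cccc(C(F)(F)F)c3)nc(Br)c3cccnc23)CC1` gives 15000 nM, which places compound 3 level with compound 2. Compound 4 `N[C@H]1CC[C@H](Nc2c(C(=O)NCc3cccs3)nc(Br)c3cccnc23)CC1` has not been measured yet. It keeps the shared core of compound 3 and differs in one group: thiophen-2-yl in place of 3-(trifluoromethyl)phenyl on a saturated chain carbon bound to an amide-type nitrogen. Among the measured compounds shown here, only one measured step bears on this change: 3-(trifluoromethyl)phenyl in place of pyridin-2-yl at that same place gave no change at the digits printed from compound 2 to compound 3 (within the scatter). This is thin evidence, since neither compound 2 nor compound 3 carries thiophen-2-yl. Even so, nothing measured points either way, so no shift beyond the scatter is expected in this assay, and no direction can be favoured. The expected change is no change at the digits printed from compound 3 to compound 4 (within the scatter). The estimate for compound 4 is 15000 nM, with an expected range of 7000 nM to 30000 nM.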

Compound 4, half-maximal inhibitory concentration: 7300 nM
The estimate for compound 4 lay 2.1-fold (0.31 log units) above the measured number, and the stated range covers the measured number.
By their numbers in this assay, from the lowest: compound 4; then compounds 2 and 3 (each within the scatter of the next).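

In this assay, the earlier swap at this place, on a saturated chain carbon bound to an amide-type nitrogen, had moved nothing, so the group there might have seemed not to matter. Thiophen-2-yl is the first group shown to shift the number beyond the scatter, with a 2.1-fold lower number from compound 3 to compound 4 (0.31 log units; beyond the scatter) and a 2.1-fold lower number from compound 2 to compound 4 (0.31 log units; beyond the scatter), so this place does respond to a change of group, though only modestly here. Nothing available explains why the number fell.

Still open, on these data alone, is whether the shift belongs to the sulfur atom or to the five-membered ring, which a furan-2-yl or a plain phenyl group at this place could help to separate. Also open, as far as these compounds go, is whether the lower number would survive a longer chain between the amide nitrogen and the ring.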